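A few compounds are considered here, and "the series" means these few. Any claim that something is new, unique, unknown or untested is made for them only; others in the source may bear on it.

Measured in an ADME assay on Vero cells (Chlorocebus sabaeus) for cytotoxicity, with a stated time of 5 days; on this read-out lower numbers stand for stronger inhibition and higher numbers for weaker inhibition:

Compound 1 `COc1nc(F)nc2c1ncn2[C@H]1C[C@H](N=[N+]=[N-])[C@@H](CO)O1`: > 100000 nM (a limit)
Compound 2 `[N-]=[N+]=N[C@H]1C[C@H](n2cnc3c(Cl)nc(F)nc32)O[C@@H]1CO`: 21800 nM
Compound 3 `COc1nc(N)c2ncn([C@H]3C[C@H](N=[N+]=[N-])[C@@H](CO)O3)c2n1`: > 100000 nM (a limit)

Compound 3 sits at the limit of > 100000 nM in this assay, at which 2 of the 3 values shown sit, so it has a limit and no number in this assay. Compound 4 `[N-]=[N+]=N[C@H]1C[C@H](n2cnc3c(N)nc(F)nc32)O[C@@H]1CO` differs from compound 3 by fluoro in place of methoxy on an aromatic carbon, between two ring nitrogen atoms: fluoro in place of methoxy on an aromatic carbon.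

Among the measured compounds shown here, only one measured step bears on this change. It is an at least 4.5-fold lower number from compound 1 to compound 2 (0.66 log units; beyond the scatter), which also replaces methoxy on an aromatic carbon, though with chloro rather than fluoro, so it is a loose guide. Going by that step, a move to a lower number of modest size is expected, with a real chance that the value stays at the limit. The expected change is an at least 3.3-fold lower number from compound 3 to compound 4 (0.52 log units; beyond the scatter). Compound 4 is estimated at 30000 nM. The expected range for compound 4 runs from 8000 nM to 100000 nM.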

Compound 4, half-maximal inhibitory concentration: 34400 nM
Beside the measured number, compound 4's estimate is 1.1-fold (0.06 log units) below it, within the range that was stated.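

In this assay, the methoxy group proves to matter on the aromatic carbon between two ring nitrogen atoms as well, not only on the other substituted carbon of the core: an at least 2.9-fold lower number from compound 3 to compound 4 (0.46 log units; beyond the scatter). On that other carbon, amino in place of methoxy also gives a lower number, an at least 2.9-fold lower number from compound 1 to compound 4 (0.46 log units; beyond the scatter), while amino in place of chloro shows no difference beyond the scatter, a 1.6-fold higher number from compound 2 to compound 4 (0.20 log units; within the scatter). Both steps away from methoxy start from a compound that has only a limit, so they give just a minimum size: the limit of > 100000 nM in this assay, at which 2 of the 4 values shown sit.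

Going by these compounds, the true size of those two steps stays open. So does whether a hydroxy, ethoxy or dimethylamino group in place of the fluoro on this carbon would keep a measurable value or return to the limit.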